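A Fluoro Group Added to Compound 2

The source may report more compounds than this note shows. Statements on the series, on what has been measured and on what is new or still open speak of the compounds shown alone.

Two related compounds begin this account: compound 1 `CC1=C(c2ccc(S(C)(=O)=O)cc2)C(c2ccc(OC[C@H](C)N3CC[C@@H](C)C3)cc2)Oc2ccc(O)cc21` and compound 2 `CC1=C(c2ccccc2)C(c2ccc(OC[C@H](C)N3CC[C@@H](C)C3)cc2)Oc2ccc(O)cc21`. In an ADME assay on the whole organism for pharmacokinetics, with Mus musculus as the target, at a dose of 10 mg/kg by the oral route (a lower number here means less compound in the circulation, a higher number more compound in the circulation at the dose given), the result for compound 1 is "not determined" (no result reported), so there is nothing to compare. Among the measured compounds shown here, compound 2 gives 1000 ng.h/mL, the only number available, so it cannot yet be called high or low against any neighbour. Compound 3 `CC1=C(c2cccc(F)c2)C(c2ccc(OC[C@H](C)N3CC[C@@H](C)C3)cc2)Oc2ccc(O)cc21` differs from compound 2 in one place: fluoro in place of hydrogen on an aromatic carbon. For the measured compounds named here, no measured pair shows what such a change does in this assay, so the expectation is a small step, with no firm direction and nothing beyond the usual scatter. The step expected is a 1.1-fold higher number from compound 2 to compound 3 (0.04 log units; within the scatter). For compound 3 the estimated value is 1100 ng.h/mL, with an expected range from 500 ng.h/mL to 2400 ng.h/mL.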

Compound 3, area under the concentration-time curve: 350 ng.h/mL
Beside the measured number, compound 3's estimate is 3.1-fold (0.50 log units) above it; measured number outside the range, below it.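

Among the compounds shown here, the change from hydrogen to fluoro gives a 2.9-fold lower number from compound 2 to compound 3 (0.46 log units; beyond the scatter) in this assay and is the first measured step, so the phenyl ring of compound 2 now has a position with a known response. A single added fluorine, on an aromatic carbon meta to a large group, is enough to move this read-out beyond the usual scatter, which means that this position cannot be treated as indifferent to a small substitution. No measurement shown here explains the lower number, so it stands as an observation without a known cause.

One pair cannot show whether this step is particular to fluoro or would also appear with another group at this position, such as chloro, methoxy or an amine. It also leaves open whether fluoro elsewhere on the same ring would give a step of similar size or direction.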